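This account rests on a few compounds, and the source may have more. Where it says the series, first, only, none or still open, it means among the compounds named here.

Measured so far in a functional assay on PC-3 cells (Homo sapiens) for antiproliferative activity, read by MTT assay, with a stated time of 48 h; a higher number here means a weaker inhibitor, a lower number a stronger inhibitor:

Compound 1, `O=C(/C=C\Nc1ccc(O)cc1)c1cn(-c2ccccc2)nc1-c1ccccc1`, gives 3600 nM.
Compound 2, `COc1cc(N/C=C\C(=O)c2cn(-c3ccccc3)nc2-c2ccc(F)cc2)cc(OC)c1OC`, gives 4890 nM.

Both compounds share a core in which an enaminone chain links a pyrazole to an aniline ring. Compound 2 shows the higher of the two numbers, but the gap to compound 1 lies within the usual scatter of repeated measurements, so the two cannot be told apart on these data.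

Compound 3, `COc1ccc(-c2nn(-c3ccccc3)cc2C(=O)/C=C\Nc2cc(OC)c(OC)c(OC)c2)cc1`, is not yet measured in this assay. It differs from compound 2 in one place: methoxy in place of fluoro on an aromatic carbon. In words, methoxy replaces fluoro on the aryl ring attached to the pyrazole, so the 4-fluorophenyl becomes 4-methoxyphenyl.

Among the compounds with values here, no pair of measured compounds here isolates this kind of swap, so there is no measured step to lean on. A small substituent exchange at that position is expected to give a step from compound 2 to compound 3 of a 1.1-fold lower number from compound 2 to compound 3 (0.04 log units; within the scatter), which means no change beyond the scatter in either direction. On that basis compound 3 is estimated to give 4500 nM, with a range from 2000 nM to 10000 nM.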

Compound 3, half-maximal inhibitory concentration: 18900 nM
The estimate for compound 3 lay 4.2-fold (0.62 log units) below the measured number; the measured number lies above the stated range.
By their numbers in this assay, from the lowest: compounds 1 and 2 (each within the scatter of the next); then compound 3.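

In this assay, the place that holds the 4-fluorophenyl in compound 2 proves sensitive to its substituent: changing it to 4-methoxyphenyl gives a 3.9-fold higher number from compound 2 to compound 3 (0.59 log units; beyond the scatter). This is the first change shown here that is confined to one place, and it moves the compound towards weaker inhibition, even though it is a small exchange on an aromatic carbon, para to a large group: one heavy atom leaves, two enter, and one hydrogen-bond acceptor is gained. No measurement at hand bears on why the number rises.

From the compounds shown here alone, whether a chlorine atom, an amine or a longer chain such as ethoxy at this same place would stay close to compound 2 or rise as compound 3 does remains open, so one step cannot show whether the change is specific to methoxy. Within the data shown here, it also remains open whether the same swap would give a similar step with the aniline ring of compound 1 in place of the one carried by compound 2 and compound 3.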